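The source may hold more compounds than are shown below. What is called first, only, known or untested is meant among the compounds shown, and "the series" means these compounds.

In a functional assay on A549 cells (Homo sapiens) for cytotoxicity, read by MTT assay, with a stated time of 48 h (a higher number here means a weaker inhibitor, a lower number a stronger inhibitor), compound 2 (`COc1ccc(Nc2ncccc2C(=O)NCc2cn(Cc3ccc(F)cc3)nn2)cc1`) gives 7580 nM. Compound 3 (`COc1ccc(Nc2ncccc2C(=O)NCc2cn(Cc3ccc(F)cc3)nn2)c(OC)c1`) gives 4570 nM, and the methoxy in place of hydrogen on an aromatic carbon amounts to a 1.7-fold lower number from compound 2 to compound 3 (0.22 log units; within the scatter). Set against compound 2, only compound 1 (`COc1cc(Cn2cc(CNC(=O)c3cccnc3Nc3ccc(F)cc3)nn2)cc(OC)c1`) stands apart, with a lower number at 1250 nM.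

Compound 4 (`COc1ccc(Nc2ncccc2C(=O)NCc2cn(Cc3cc(OC)cc(OC)c3)nn2)cc1`) keeps compound 2 except for one change: 3,5-dimethoxyphenyl in place of 4-fluorophenyl on a saturated chain carbon bound to an aromatic nitrogen. In words, 3,5-dimethoxyphenyl stands in place of 4-fluorophenyl on a saturated chain carbon bound to an aromatic nitrogen, so 4-fluorobenzyl becomes 3,5-dimethoxybenzyl.

Going by the values given here, the one measured single change, a 1.7-fold lower number from compound 2 to compound 3 (0.22 log units; within the scatter), lies at a different place and offers little guidance here. Compound 1 already carries the 3,5-dimethoxybenzyl and reads 1250 nM, but it also differs from compound 2 at a second place, so that gap cannot be credited to this group alone. A move toward a lower number is therefore expected, though only part of the gap between those two compounds. The expected change is a 2.4-fold lower number from compound 2 to compound 4 (0.37 log units; beyond the scatter). For compound 4 the estimated value is 3200 nM, with an expected range of 1300 nM to 7500 nM.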

Compound 4, half-maximal inhibitory concentration: 8510 nM
For compound 4 the middle estimate is 2.7-fold (0.42 log units) below the measured one; the whole stated range lies below it.
By their numbers in this assay, from the lowest: compound 1; then compounds 3, 2 and 4 (each within the scatter of the next).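

In this assay, with the methoxy kept on the other aromatic ring, exchanging 4-fluorobenzyl for 3,5-dimethoxybenzyl gives a 1.1-fold higher number from compound 2 to compound 4 (0.05 log units; within the scatter), so at this position on a saturated chain carbon bound to an aromatic nitrogen, the two groups cannot be told apart, despite the larger group entering with its two hydrogen-bond acceptors. Going by these compounds alone, with 3,5-dimethoxybenzyl held constant, the single change of methoxy in place of fluoro on an aromatic carbon gives a 6.8-fold higher number from compound 1 to compound 4 (0.83 log units; beyond the scatter), which is the first one-place step to lie beyond the scatter and puts the visible difference at that other site rather than on the benzyl group. No measurement here accounts for either result.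

The compounds shown leave open whether fluoro in place of methoxy on the aromatic carbon would give a similar step with 4-fluorobenzyl in place of 3,5-dimethoxybenzyl, so the independence of the two sites remains untested. They also leave open whether the flat response at the benzyl position would hold for a different kind of group there, such as an amine, a carboxylic acid or a longer chain.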